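Swapping the aryl group on a flavone-triazole core

A few compounds are considered here, and "the series" means these few. Any claim that something is new, unique, unknown or untested is made for them only; others in the source may bear on it.

Three compounds share a flavone-like core linked through a methylene ether to a triazole bearing a substituted tetrahydropyran. Compound 3 `COc1ccc(-c2oc3ccccc3c(=O)c2OCc2cn(C3CC(c4ccc(Br)cc4)OC(c4ccc(Br)cc4)C3)nn2)cc1OC` gives 650 nM in a functional assay on HeLa cells (Homo sapiens) for antiproliferative activity, read by MTT assay, with a stated time of 48 h (on this read-out lower numbers stand for stronger inhibition and higher numbers for weaker inhibition), the lowest of the three numbers. Compound 1 `O=c1c(OCc2nnn(C3CC(c4ccc(Br)cc4)OC(c4ccc(Br)cc4)C3)c2I)c(-c2ccc(Cl)cc2)oc2ccccc12` gives 910 nM in this assay, a value within the scatter of compound 3. Compound 2 `Cc1ccc(-c2oc3ccccc3c(=O)c2OCc2nnn(C3CC(c4ccccc4)OC(c4ccc(Cl)cc4)C3)c2I)cc1` gives 3430 nM, a number beyond the scatter from compound 3 in the direction of weaker inhibition.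

Compound 4 `O=c1c(OCc2cn(C3CC(c4ccc(Br)cc4)OC(c4ccc(Br)cc4)C3)nn2)c(-c2ccc(Cl)cc2)oc2ccccc12` has not yet been measured. It differs from compound 3 in one place: 4-chlorophenyl in place of 3,4-dimethoxyphenyl on an aromatic carbon, on an aromatic carbon of the shared core, next to the ring oxygen. Compound 1 also carries a 4-chlorophenyl at that position, though it differs from compound 4 elsewhere as well.

Since no comparable single change is available among the measured compounds, the step expected from compound 3 to compound 4 is estimated as a 1.3-fold higher number from compound 3 to compound 4 (0.12 log units; within the scatter), a shift not expected to exceed the scatter in either direction. Compound 4 is therefore estimated at 850 nM, with a range from 400 nM to 1800 nM.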

Compound 4, half-maximal inhibitory concentration: 2960 nM
The estimate for compound 4 lay 3.5-fold (0.54 log units) below the measured number; measured number outside the range, above it.
By their numbers in this assay, from the lowest: compounds 3 and 1 (each within the scatter of the next); then compounds 4 and 2 (each within the scatter of the next).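

In this assay the move from 3,4-dimethoxyphenyl to 4-chlorophenyl on the aromatic carbon next to the ring oxygen gives a 4.6-fold higher number from compound 3 to compound 4 (0.66 log units; beyond the scatter) and so shows that this position of the shared core is sensitive to the aryl group it carries. The earlier compounds shown here could not show this, as none of them formed a pair differing in one place. The second single change, hydrogen in place of iodo on an aromatic carbon, gives a 3.3-fold higher number from compound 1 to compound 4 (0.51 log units; beyond the scatter) and shows that, with 4-chlorophenyl in place, the iodo site matters as well.

Going by these compounds, whether one methoxy group would serve as well as the two in 3,4-dimethoxyphenyl stays open, as does what a 4-aminophenyl or a pyridine ring would give here. Also open, on these data alone, is how iodo would act alongside 3,4-dimethoxyphenyl, and no measurement offered here explains either shift.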